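Notes on the methoxy move from compound 3 to compound 4

This account rests on a few compounds, and the source may have more. Where it says the series, first, only, none or still open, it means among the compounds named here.

Measured compounds and values in a functional assay on HCC827 cells (Homo sapiens) for inhibition, read by fluorescence and resazurin assay, with a stated time of 72 h; on this read-out lower numbers stand for stronger inhibition of growth and higher numbers for weaker inhibition of growth:
compound 1 `N[C@H]1CC[C@H](Nc2nc(Nc3ccc(-c4ccccc4O)cc3)c3ncn(C4CCCC4)c3n2)CC1` 2530 nM
compound 2 `Nc1ccccc1-c1ccc(Nc2nc(N[C@H]3CC[C@H](N)CC3)nc3c2ncn3C2CCCC2)cc1` 810 nM
compound 3 `COc1ccccc1-c1ccc(Nc2nc(N[C@H]3CC[C@H](N)CC3)nc3c2ncn3C2CCCC2)cn1` 638 nM

Compound 3 gives the lowest number of the three. Against compound 2 the gap is within the scatter, so no order between the two can be read; against compound 1 the gap is beyond the scatter.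

Compound 4 `COc1ccc(-c2ccc(Nc3nc(N[C@H]4CC[C@H](N)CC4)nc4c3ncn4C3CCCC3)cn2)cc1` is not yet measured. It differs from compound 3 in one place: 4-methoxyphenyl in place of 2-methoxyphenyl on an aromatic carbon. The same atoms are present, only joined differently.

Among the compounds with values here, only one step has been measured between compounds that differ in one place, a 3.1-fold lower number from compound 1 to compound 2 (0.49 log units; beyond the scatter), and it concerns an exchange of amino for hydroxy, not a move of a methoxy group around a ring. Within the data shown here, no measured pair shows what moving the methoxy group does, so no direction can be taken from the data. Given that the change keeps the methoxyphenyl group and the rest of the structure, the expectation is a step of a 1.1-fold higher number from compound 3 to compound 4 (0.04 log units; within the scatter), that is, nothing beyond the scatter in either direction.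

Compound 4 is therefore expected at about 700 nM, with a range of 250 nM to 2000 nM in this assay.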

Compound 4, concentration for 50% growth inhibition: 581 nM
For compound 4 the middle estimate is 1.2-fold (0.08 log units) above the measured one, and the stated range covers the measured number.
By their numbers in this assay, from the lowest: compounds 4, 3 and 2 (each within the scatter of the next); then compound 1.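

In this assay the series now has its first measured move of a methoxy group around a ring, and exchanging 2-methoxyphenyl for 4-methoxyphenyl gives a 1.1-fold lower number from compound 3 to compound 4 (0.04 log units; within the scatter). At this place, on an aromatic carbon next to the ring nitrogen and para to a large group, the two arrangements of the same atoms cannot be told apart on this read-out, which the earlier exchange of amino for hydroxy could not show, as it concerned a different change on a different ring. No measurement at hand bears on this result.

Still open, from the compounds shown here alone, is whether this insensitivity to the methoxy location holds for other groups on the same phenyl ring, such as an amine, a carboxylic acid or a longer chain like ethoxy. Within the data shown here, also open is whether the same methoxy move would read alike on the six-membered aromatic ring of carbon only that compound 1 and compound 2 carry in place of the ring with one nitrogen.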